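Anilino in place of hydroxy: a small expected change

A few compounds are considered here, and "the series" means these few. Any claim that something is new, unique, unknown or untested is made for them only; others in the source may bear on it.

Results so far in a functional assay on NCI-H460 cells (Homo sapiens) for inhibition, read by MTT assay, with a stated time of 24 h, tested at 0.1 ug/mL (a lower number here means less inhibition of growth, a higher number more inhibition of growth at the concentration tested), are these
Compound 1 `O=C(O)CCCCC(CCSC(=O)c1ccccc1)SC(=O)c1ccccc1` gives "not active" (no number reported)
Compound 2 `O=C(CCCCC1CCSS1)Nc1ccc(OC(F)(F)F)cc1` gives 7.05%
Compound 3 `CC(=O)SCCC(CCCCC(=O)Nc1ccc(Cl)cc1)SC(C)=O` gives 9.89%

Compound 1 has no single number, only the verdict "not active" (no number reported) in place of a value, so any step from it can be judged only loosely. Compound 4 `O=C(CCCCC(CCSC(=O)c1ccccc1)SC(=O)c1ccccc1)Nc1ccccc1` is still unmeasured. Its change is simple to describe: anilino in place of hydroxy on a carbonyl carbon with anilino in place of hydroxy on a carbonyl carbon. A small rise in this assay is expected, perhaps none beyond the scatter. The nearest guides are low: compound 2 gives 7.05% and compound 3 gives 9.89% in the same test. For compound 4 the estimated inhibition is 9% with 2% to 22% as the expected range.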

Compound 4, percent growth inhibition at one concentration: 0.6%
Beside the measured number, compound 4's estimate is 8.4 percentage points above it; the whole stated range lies above it.
By their numbers in this assay, from the lowest: compounds 4, 2 and 3 (each within the scatter of the next).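

Among these compounds, compound 1 carries only the verdict "not active" (no number reported) and so no step from it to compound 4 can be read. What anilino in place of hydroxy does to growth inhibition stays open, and no supporting measurement is available to explain these results.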